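Adding a methoxy group to compound 1

A few compounds are considered here, and "the series" means these few. Any claim that something is new, unique, unknown or untested is made for them only; others in the source may bear on it.

Measured in a functional assay on A549 cells (Homo sapiens) for antiproliferative activity, read by MTT assay, with a stated time of 72 h; on this read-out higher numbers stand for weaker inhibition and lower numbers for stronger inhibition:
- compound 1 `CN(C(=O)c1ccccc1)c1ccc2[nH]c(-c3n[nH]c4ccccc34)cc2n1`: 13800 nM
- compound 2 `CN(C(=O)c1ccc(F)cc1)c1ccc2[nH]c(-c3n[nH]c4ccccc34)cc2n1`: 9650 nM
- compound 3 `CN(C(=O)c1ccc(Cl)cc1)c1ccc2[nH]c(-c3n[nH]c4ccccc34)cc2n1`: 2220 nM

Compound 1 sits at the high end of these three numbers, meaning weak inhibition, but it does not stand apart from its nearest neighbour: a 1.4-fold lower number from compound 1 to compound 2 (0.16 log units; within the scatter). The next compound, compound 4 `COc1ccc(C(=O)N(C)c2ccc3[nH]c(-c4n[nH]c5ccccc45)cc3n2)cc1`, has not yet been measured. It keeps the core of compound 1 and places methoxy in place of hydrogen on an aromatic carbon of a six-membered aromatic ring of carbon only, para to a large group: methoxy in place of hydrogen on an aromatic carbon.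

Two measured steps change that same hydrogen. Fluoro gave a 1.4-fold lower number from compound 1 to compound 2 (0.16 log units; within the scatter), while chloro gave a 6.2-fold lower number from compound 1 to compound 3 (0.79 log units; beyond the scatter). The two halogen compounds also differ clearly from each other: a 4.3-fold lower number from compound 2 to compound 3 (0.64 log units; beyond the scatter). Neither compound 2 nor compound 3 contains methoxy, so they offer only a rough guide, and the two steps differ in size. A small move toward stronger inhibition in this assay therefore seems the fairest expectation, lying between those two steps. The expected change is a 2.3-fold lower number from compound 1 to compound 4 (0.36 log units; beyond the scatter). For compound 4 the estimated value is 6000 nM, with an expected range from 1800 nM to 18000 nM.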

Compound 4, half-maximal inhibitory concentration: 14600 nM
For compound 4 the middle estimate is 2.4-fold (0.39 log units) below the measured one; measured number inside the range.
By their numbers in this assay, from the lowest: compound 3; then compounds 2, 1 and 4 (each within the scatter of the next).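

In this assay, methoxy in place of hydrogen on an aromatic carbon, para to a large group, gives (a 1.1-fold higher number from compound 1 to compound 4 (0.02 log units; within the scatter)), so this larger group cannot be told apart from the plain hydrogen. The comparison with fluoro reads the same way (a 1.5-fold higher number from compound 2 to compound 4 (0.18 log units; within the scatter)), whereas the comparison with chloro shows a clear gap (a 6.6-fold higher number from compound 3 to compound 4 (0.82 log units; beyond the scatter)). Methoxy therefore joins hydrogen and fluoro in one group whose members lie within the scatter of one another, with chloro alone standing apart at this position, so placing a substituent here does not by itself bring stronger inhibition, and the added heavy atoms of methoxy bring none in this assay.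

Nothing available here explains why chloro separates from the other three groups. On these data alone, whether bromo, trifluoromethyl, an amine or a carboxylic acid at this same place would side with chloro or with the other three remains open, as does whether chloro would keep its advantage on another carbon of the same ring.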